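This account rests on a few compounds, and the source may have more. Where it says the series, first, only, none or still open, it means among the compounds named here.

In a functional assay on HCT-116 cells (Homo sapiens) for cytotoxicity, read by MTT assay (on this read-out lower numbers stand for stronger inhibition and higher numbers for weaker inhibition), compound 1 `CCc1cc(S(=O)(=O)N2C[C@H](c3ccccc3)NC2=O)ccc1NC(=O)OC(C)C` gives 60 nM, and compound 2 `CCOC(=O)Nc1ccc(S(=O)(=O)N2C[C@H](c3ccccc3)NC2=O)cc1CC` gives 70 nM. Going by the values given here, the only step measured between them, a 1.2-fold higher number from compound 1 to compound 2 (0.07 log units; within the scatter), shifts the number hardly at all. Compound 2 thus stands at one end of the two numbers recorded, yet its gap from compound 1 lies within the scatter, so the two compounds cannot be told apart on this read-out.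

Compound 3 `CCc1cc(S(=O)(=O)N2C[C@H](c3ccccc3)NC2=O)ccc1NC(=O)c1ccc([N+](=O)[O-])cc1` differs from compound 2 by 4-nitrophenyl in place of ethoxy on a carbonyl carbon. Among the compounds with values here, no measured step bears on such an exchange: the one step known concerns only the ethoxy chain that now departs, and it was itself within the scatter. The data therefore give no direction for the change, only a wide band of uncertainty.

Compound 3 is accordingly expected to show about 100 nM, with a range from 25 nM to 400 nM. The estimated step of a 1.4-fold higher number from compound 2 to compound 3 (0.15 log units; within the scatter) is expected to stay within the scatter.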

Compound 3, half-maximal inhibitory concentration: 500 nM
Compound 3: the middle estimate sits 5.0-fold (0.70 log units) below what was measured, and the stated range ends below it.
By their numbers in this assay, from the lowest: compounds 1 and 2 (each within the scatter of the next); then compound 3.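

In this assay, the carbonyl carbon whose other neighbour is the amide-type nitrogen proves sensitive to the group it carries: 4-nitrophenyl in place of ethoxy gives a 7.1-fold higher number from compound 2 to compound 3 (0.85 log units; beyond the scatter), and 4-nitrophenyl in place of isopropoxy gives an 8.3-fold higher number from compound 1 to compound 3 (0.92 log units; beyond the scatter). The earlier exchange between the two chains on this carbon stayed within the scatter, whereas both exchanges for the aromatic group go beyond it, though only modestly. No supporting data are available to explain this loss of inhibition.

Compound 3 brings in the six-membered aromatic ring and the nitro group together, so the compounds shown cannot separate the contribution of one from that of the other. On these data alone, it also remains open how an unsubstituted phenyl group, a methyl group or an amine on the same carbonyl carbon would fare.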